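Cyano for bromo on the core of compound 1

A few compounds are considered here, and "the series" means these few. Any claim that something is new, unique, unknown or untested is made for them only; others in the source may bear on it.

For the measured compounds named here, compound 1, `Nc1ccc(-c2nc3ccccc3s2)c(Br)c1`, is one of three compounds measured in a functional assay on MCF7 cells (Homo sapiens) for inhibition; a lower number here means a stronger inhibitor, a higher number a weaker inhibitor. Compound 1 stands at a limit of this assay, < 0.1 nM, so no number is known for it. Compound 2, `Cc1ccc2nc(-c3ccc(N)cc3Br)sc2c1`, also stands at a limit, < 0.1 nM. Compound 3, `Cc1cc(N)cc(Cl)c1-c1nc2ccccc2s1`, stands at a different limit, < 10 nM. Two of the three values sit at the limit of < 0.1 nM in this assay, at which 2 of the 3 values shown sit, and one at the limit of < 10 nM in this assay, at which 1 of the 3 values shown sits. Going by the values given here, the only single-point step among them, from compound 1 to compound 2, is a step that the two limits leave unreadable from compound 1 to compound 2, a methyl in place of hydrogen on an aromatic carbon. Compound 4, `N#Cc1cc(N)ccc1-c1nc2ccccc2s1`, differs from compound 1 by cyano in place of bromo on an aromatic carbon. Among the compounds with values here, no measured step touches this position, and the step from compound 1 to compound 2 tells nothing about its size. With compound 1 at a limit, the step from compound 1 to compound 4 is expected to be an at least 5.0-fold higher number from compound 1 to compound 4 (0.69 log units; beyond the scatter), with wide uncertainty. Compound 4 is therefore estimated at 0.5 nM, between 0.03 nM and 10 nM, in this assay.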

Compound 4, half-maximal inhibitory concentration: < 10 nM
Compound 4 was reported as a limit; the forecaster's own chance of this, stated with the estimate: 35%; the middle value is on the limit's open side.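

In this assay compound 4 gives only a limit, < 10 nM. Compound 1 also gives only a limit, < 0.1 nM. The step between compound 1 and compound 4 therefore cannot be read. The compounds shown leave open whether, and how far, cyano in place of bromo shifts the inhibition.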